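A few compounds are considered here, and "the series" means these few. Any claim that something is new, unique, unknown or untested is made for them only; others in the source may bear on it.

Of the compounds shown here, three built on one shared core have so far been measured in an ADME assay on J774.A1 cells (Mus musculus) for cytotoxicity, read by MTT assay, with a stated time of 72 h; a higher number here means that more compound is tolerated, a lower number that less compound is tolerated. Compound 1 `CCC1(c2ccccc2OC)CC(S(=O)(=O)c2ccc(F)cc2)=C(c2ccc(/C(N)=N\O)cc2)O1` gives 9880 nM in this assay. Compound 2 `CC1(c2ccc(-c3cccc(/C(N)=N\O)c3)cc2)CC(S(=O)(=O)c2ccc(F)cc2)=C(c2ccc(/C(N)=N\O)cc2)O1` gives 11000 nM, the second highest of the three numbers; its gap to compound 1 lies within the scatter, so the two cannot be ordered, while compound 3 `CC1(Cc2ccccc2)CC(S(=O)(=O)c2c(F)cccc2F)=C(c2ccc(/C(N)=N\O)cc2)O1` gives 27000 nM, a gap that lies beyond the scatter. Compound 4 `CC1(c2ccc(Cl)cc2)CC(S(=O)(=O)c2ccc(F)cc2)=C(c2ccc(/C(N)=N\O)cc2)O1` has not yet been measured in this assay. From compound 2 to compound 4 the structure changes by one chlorine atom in place of a group of 10 heavy atoms (7 carbon, 2 nitrogen, 1 oxygen; one six-membered aromatic ring of carbon only), on an aromatic carbon. For the measured compounds named here, no measured pair shows this change, so the expected step is set with caution: a slight rise, or none beyond the scatter. For compound 4 the expected value is 13000 nM, with a range from 5500 nM to 30000 nM. This amounts to an expected step of a 1.2-fold higher number from compound 2 to compound 4 (0.07 log units; within the scatter).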

Compound 4, half-maximal cytotoxic concentration: 31500 nM
Estimate against measurement, compound 4: 2.4-fold (0.38 log units) below, outside the stated range (above it).
By their numbers in this assay, from the lowest: compounds 1 and 2 (each within the scatter of the next); then compounds 3 and 4 (each within the scatter of the next).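

Replacing the large group with a single chloro on this aromatic carbon, para to a large group, gives a 2.9-fold higher number from compound 2 to compound 4 (0.46 log units; beyond the scatter) in this assay. For the compounds shown here, this is the first change between two measured compounds that differ in one place, and it shows that what sits on this carbon can shift how much compound the cells tolerate. Nothing available explains the shift.

Going by these compounds, the large group left as a whole, so the part responsible remains unknown. On these data alone, whether an amine or a carboxylic acid on this carbon would give a similar number also stays open.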